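The source may report more compounds than this note shows. Statements on the series, on what has been measured and on what is new or still open speak of the compounds shown alone.

Measured in an ADME assay on Vero 76 cells (Chlorocebus sabaeus) for cytotoxicity, read by microscopy; a lower number here means that less compound is tolerated, a higher number that more compound is tolerated:

- compound 1 `CC(C)[C@@H](Nc1nc(Cl)nc2c1ncn2[C@H]1[C@H](O)[C@H](O)[C@]2(CCl)C[C@H]12)C1CC1`: 32000 nM
- compound 2 `CC(C)C(Nc1nc(Cl)nc2c1ncn2[C@H]1[C@H](O)[C@H](O)[C@]2(CO)C[C@H]12)C(C)C`: > 100000 nM (a limit of the assay, not a number)
- compound 3 `CC(C)[C@@H](Nc1nc(I)nc2c1ncn2[C@H]1[C@H](O)[C@H](O)[C@]2(CO)C[C@H]12)C1CC1`: 100000 nM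

Compound 2 is the starting point of this account, and it stands at > 100000 nM. This is a limit and not a number: the limit of > 100000 nM in this assay, at which 1 of the 3 values shown sits.

The compound still awaiting measurement is compound 4 `OC[C@@]12C[C@@H]1[C@@H](n1cnc3c(NCc4ccccc4)nc(Cl)nc31)[C@H](O)[C@@H]2O`. Its difference from compound 2 is benzyl in place of 1-isopropyl-2-methylpropyl on a nitrogen on an aromatic ring. In words, benzyl takes the place of 1-isopropyl-2-methylpropyl on a nitrogen on an aromatic ring, which brings in one six-membered aromatic ring of carbon only.

Going by the values given here, no measured pair isolates this change, so its size in this assay can only be expected. The other values give a loose guide. Compound 3 gives 100000 nM and compound 1 gives 32000 nM, so exact numbers do occur among these compounds. The expectation is therefore a small step toward less compound tolerated, probably none beyond the usual scatter. The expected change is an at least 1.4-fold lower number from compound 2 to compound 4 (0.15 log units; that floor lies within the scatter). For compound 4 the estimated value is 70000 nM, with an expected range from 25000 nM to 100000 nM.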

Compound 4, half-maximal cytotoxic concentration: > 100000 nM
Compound 4: a limit, no number; the forecaster's own chance of this, stated with the estimate: 45%; middle value at least 1.4-fold (0.15 log units) away from the limit.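

In this assay compound 4 gives > 100000 nM, a limit of the assay and not a number. Compound 2 gives > 100000 nM, which is also a limit, so no step can be read between compound 2 and compound 4. The compounds shown leave open how benzyl and 1-isopropyl-2-methylpropyl on a nitrogen on an aromatic ring compare in this assay.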